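Chain extension from compound 2 to compound 3

The source may hold more compounds than are shown below. What is called first, only, known or untested is meant among the compounds shown, and "the series" means these compounds.

In an ADME assay on PBMC cells (Homo sapiens) for cytotoxicity (on this read-out lower numbers stand for higher toxicity in this test and higher numbers for lower toxicity in this test), compound 1 (`CCCCCC(=O)Nc1nc(N)nc2c1ncn2[C@H]1CO[C@@H](CO)O1`) gives > 100000 nM as a limit of the assay. Compound 2 (`CCCCCCCC(=O)Nc1nc(N)nc2c1ncn2[C@H]1CO[C@@H](CO)O1`) gives > 100000 nM as a limit of the assay too, so it stands on no measured number. Compound 3 (`CCCCCCCC/C=C\CCCCCCCC(=O)Nc1nc(N)nc2c1ncn2[C@H]1CO[C@@H](CO)O1`) carries dec-1-en-1-yl in place of hydrogen on a saturated chain carbon, seven bonds along the chain from a carbonyl carbon relative to compound 2. Among the compounds with values here, the only measured step bearing on this is a step that the two limits leave unreadable from compound 1 to compound 2 and it sets no size, with both values at the same limit (the limit of > 100000 nM in this assay, at which 2 of the 2 values shown sit). The expected change is a number no higher from compound 2 to compound 3 (the limit leaves the size open) in this assay and it is not expected to exceed the scatter. Compound 3 is estimated at 100000 nM with an expected range from 40000 nM to 200000 nM and probably another limit reading.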

Compound 3, half-maximal cytotoxic concentration: 76000 nM
For compound 3 the middle estimate is 1.3-fold (0.12 log units) above the measured one, and the stated range covers the measured number.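

With dec-1-en-1-yl at the saturated chain carbon seven bonds along the chain from a carbonyl carbon, this assay gives its first readable value in this set, with an at least 1.3-fold lower number from compound 2 to compound 3 (0.11 log units; that floor lies within the scatter). Read as dodec-3-en-1-yl five bonds along the chain from a carbonyl carbon, the change gives an at least 1.3-fold lower number from compound 1 to compound 3 (0.11 log units; that floor lies within the scatter). The remaining step cannot be read: the limit of > 100000 nM in this assay, at which 2 of the 3 values shown sit.

Going by these compounds, the true size of both readable steps stays open. So does the separate contribution of chain length and the double bond, which a fully saturated chain of the same length or a chain ending in a carboxylic acid could help resolve.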